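A few compounds are considered here, and "the series" means these few. Any claim that something is new, unique, unknown or untested is made for them only; others in the source may bear on it.

For the measured compounds named here, in an ADME assay (liver, Mus musculus) for metabolic stability, using microsomes (a higher number here means that the compound lasts longer, a lower number that the compound disappears faster), compound 1 `CCc1nc2cc(Cl)ccn2c1C(=O)NCc1ccc(-c2ccc(C)cc2)cc1` gives 0.385 h, the only exact number in this small set. Compound 2 `CCc1nc2cc(Cl)ccn2c1C(=O)NCc1ccc(-c2ccc(C(=O)O)cc2)cc1` reads > 2 h, which is a limit of the assay and not a number. Going by the values given here, the one measured step, an at least 5.1-fold higher number from compound 1 to compound 2 (0.71 log units; beyond the scatter), puts carboxy in place of methyl on an aromatic carbon and lies beyond the scatter.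

Compound 3 `CCc1nc2cc(Cl)ccn2c1C(=O)NCc1ccc(N2CC3CCCCC3C2)cc1` keeps the core of compound 1 but makes a larger exchange: a group of 9 heavy atoms (8 carbon, 1 nitrogen; one five-membered non-aromatic ring with 1 hetero atom, one six-membered non-aromatic ring of carbon only) in place of a group of 7 heavy atoms (7 carbon; one six-membered aromatic ring of carbon only), on an aromatic carbon. The 4-methylphenyl leaves entirely, and a five-membered non-aromatic ring with 1 hetero atom and a six-membered non-aromatic ring of carbon only enter in its place, on an aromatic carbon para to a large group.

Only the carboxy step bears on this, and only loosely. The entering group carries no carboxy and no net charge, so the size of an at least 5.1-fold higher number from compound 1 to compound 2 (0.71 log units; beyond the scatter) does not carry over. With a single step as a guide, the direction stays uncertain and the range must be wide.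

The expected change, a 1.3-fold lower number from compound 1 to compound 3 (0.11 log units; within the scatter), is estimated to stay within the scatter. Compound 3 is expected at 0.3 h in this assay, with an estimated range of 0.12 h to 0.9 h.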

Compound 3, half-life: 0.105 h
The estimate for compound 3 lay 2.9-fold (0.46 log units) above the measured number; the whole stated range lies above it.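

The position on an aromatic carbon para to a large group now moves the number in this assay in both directions: the carboxy exchange raised it, while replacing 4-methylphenyl with the group carrying a five-membered non-aromatic ring with 1 hetero atom and a six-membered non-aromatic ring of carbon only gives a 3.7-fold lower number from compound 1 to compound 3 (0.56 log units; beyond the scatter). The choice of group at this one place therefore spans an at least 19-fold lower number from compound 2 to compound 3 (1.27 log units; beyond the scatter), the largest step in the set. That span is only a minimum, because compound 2 stands at a limit of the assay and not at a number: the limit of > 2 h in this assay, at which 1 of the 3 values shown sits.

The exchange in compound 3 removes the aromatic ring, brings in a ring nitrogen on the aromatic carbon and adds non-aromatic rings all at once, and the compounds shown do not separate these changes or give a cause for the lower number. From the compounds shown here alone, how a plain phenyl, a morpholine ring or a methyl ester at the same place would read in this assay also stays open.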